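The source may report more compounds than this note shows. Statements on the series, on what has been measured and on what is new or still open speak of the compounds shown alone.

Four compounds built on one shared core were compared in a functional assay on HCT-116 cells (Homo sapiens) for cytotoxicity, read by MTT assay, with a stated time of 48 h; on this read-out higher numbers stand for weaker inhibition and lower numbers for stronger inhibition. Compound 1 `CNC(=O)c1ccc(Sc2ccc(NC(=S)Nc3ccc(OC(F)(F)F)cc3)cc2)nc1` gave only a limit of the assay, > 100000 nM. Compound 2 `CNC(=O)c1ccc(Sc2ccc(NC(=O)Nc3ccc(Cl)c(C(F)(F)F)c3)cc2)nc1` gave 5290 nM. Compound 3 `CNC(=O)c1ccc(Sc2cccc(NC(=S)Nc3ccc(Br)c(C(F)(F)F)c3)c2)nc1` gave 16500 nM, the higher of the two measured numbers, and its gap to compound 2 lies beyond the usual scatter. Compound 4 `CNC(=O)c1ccc(Sc2cccc(NC(=S)Nc3ccc(F)c(C(F)(F)F)c3)c2)nc1` has not yet been measured; it differs from compound 3 by fluoro in place of bromo on an aromatic carbon, the exchanged halogen sitting ortho to a trifluoromethyl group and para to a large group. Among the compounds with values here, no single-place step among the measured compounds bears on this exchange. The step of a 1.2-fold higher number from compound 3 to compound 4 (0.08 log units; within the scatter) is expected to be small, no larger than the scatter. Compound 4 is estimated at 20000 nM in this assay, with a range from 8000 nM to 50000 nM.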

Compound 4, half-maximal inhibitory concentration: 18200 nM
For compound 4 the middle estimate is 1.1-fold (0.04 log units) above the measured one; measured number inside the range.
By their numbers in this assay, from the lowest: compound 2; then compounds 3 and 4 (each within the scatter of the next). At a limit, above all of these: compound 1.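

In this assay, within the data shown here, the only single-place comparison in the set gives a 1.1-fold higher number from compound 3 to compound 4 (0.04 log units; within the scatter) and so shows that, at this aromatic carbon ortho to a trifluoromethyl group, fluoro in place of bromo does not move the number beyond the scatter. This assay therefore does not tell these two halogens apart at this position on the shared core. Nothing measured here bears on why this exchange makes so little difference.

As far as these compounds go, it remains open whether a methoxy group, an amine or a carboxylic acid at this carbon would shift the number. From the compounds shown here alone, it also remains open whether the same halogen exchange would prove as small on the core of compound 2.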